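Aryl exchange on the shared core

The source may hold more compounds than are shown below. What is called first, only, known or untested is meant among the compounds shown, and "the series" means these compounds.

compound 1 `O=C(NO)c1ccc(NCc2nc(-c3ccco3)nn2-c2ccccc2)cc1`: 59.9%
compound 2 `O=C(NO)c1ccc(NCc2nc(-c3ccccc3)nn2-c2ccc(F)cc2)cc1`: 67.6%

In an assay on Sf9 cells for inhibition of protein deacetylase HDAC6 (Homo sapiens), read by fluorescence, with a stated time of 40 min, tested at 100 nM (a higher number here means more inhibition at the concentration tested (going by the name of the read-out), a lower number less inhibition), compound 1 gives 59.9%, the lower of the two numbers. Compound 2 gives 67.6%, which lies within the scatter of compound 1, so the two cannot be told apart. Compound 3 `CC(C)c1ccc(-c2nc(CNc3ccc(C(=O)NO)cc3)n(-c3ccccc3)n2)cc1` has not been measured; it carries 4-isopropylphenyl in place of furan-2-yl on an aromatic carbon. Among the measured compounds shown here, no step between measured compounds is available to size such an exchange on the shared core. The step of a number 2.1 percentage points higher from compound 1 to compound 3 (within the scatter) is therefore expected to stay small, with no direction beyond the scatter, since compound 1 gives 59.9% as the only anchor. Compound 3 is expected to give about 62% in this assay, within 42% to 80%.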

Compound 3, a percentage reported as inhibition, at one concentration (the size of the read-out at that concentration, not a potency): 27.6%
Estimate against measurement, compound 3: 34.4 percentage points above; the whole stated range lies above it.
By their numbers in this assay, from the lowest: compound 3; then compounds 1 and 2 (each within the scatter of the next).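

At this position, on an aromatic carbon of a five-membered aromatic ring with 3 nitrogen, replacing furan-2-yl with 4-isopropylphenyl in this assay gives a number 32.3 percentage points lower from compound 1 to compound 3 (beyond the scatter). Among the compounds shown here, this is the first sized step and shows that the position is sensitive to at least this exchange. Nothing available accounts for the size of the step.

Going by these compounds, whether the loss follows the isopropyl group or the change of ring remains open. A 4-methylphenyl or 4-aminophenyl group on the core of compound 1 would test how far the step extends.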